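Amino for nitro in two sulfones inactive toward fibroblasts

The compounds below may be only part of what the source reports. "The series", "measured", "known", "first", "only" and "open" are said of these compounds alone.

Compound 1, `COc1ccc(CS(=O)(=O)/C=C/c2ccc(OC)c(OC)c2OC)cc1[N+](=O)[O-]`: in an ADME assay on MRC5 cells (Homo sapiens) for cytotoxicity, read by MTT assay, with a stated time of 72 h (a higher number here means a weaker inhibitor of growth, a lower number a stronger inhibitor of growth), compound 1 gives > 30000 nM, which is a limit of the assay and not a number.
Compound 2, `COc1ccc(CS(=O)(=O)/C=C/c2ccc(OC)c(OC)c2OC)cc1N`: in this assay compound 2 gives > 30000 nM, again a limit.
Compound 3, `COc1ccc(CS(=O)(=O)CC(=O)Nc2ccccc2)cc1[N+](=O)[O-]`: in this assay compound 3 gives > 30000 nM, also a limit.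

Compound 4, `COc1ccc(CS(=O)(=O)CC(=O)Nc2ccccc2)cc1N`, has not yet been measured. The change from compound 3 to compound 4, (amino in place of nitro on an aromatic carbon), is the same change as that from compound 1 to compound 2, (amino in place of nitro on an aromatic carbon). The measured step that the two limits leave unreadable from compound 1 to compound 2 cannot be sized, as both ends are limits. How the core of compound 3 differs from the core of compound 1 is not broken down here. Among the measured compounds shown here, every value so far sits at the limit of > 30000 nM in this assay, at which 3 of the 3 values shown sit. On that basis compound 4 is expected to show a step of a number no higher from compound 3 to compound 4 (the limit leaves the size open). This rests on (the limit of > 30000 nM in this assay, at which 3 of the 3 values shown sit), which gives no sign of any change. Compound 4 is therefore estimated at 30000 nM.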

Compound 4, concentration for 50% growth inhibition: > 30000 nM
Compound 4: a limit, no number; the forecaster's own chance of this, stated with the estimate: 85%; the middle value sits exactly at the limit.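

No new step can be read from compound 3 to compound 4, as both ends are limits and not numbers: the limit of > 30000 nM in this assay, at which 4 of the 4 values shown sit. The compounds shown leave open whether amino in place of nitro alters growth inhibition in either pair.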